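A few compounds are considered here, and "the series" means these few. Any claim that something is new, unique, unknown or untested is made for them only; others in the source may bear on it.

Compound 1 `O=[N+]([O-])c1cc(C(F)(F)F)cc([N+](=O)[O-])c1Oc1ccccc1/C=N\OCc1ccccc1` gives 1330 nM in a functional assay on MCF7 cells (Homo sapiens) for antiproliferative activity, read by MTT assay, with a stated time of 48 h; a higher number here means a weaker inhibitor, a lower number a stronger inhibitor. Compound 2 `O=[N+]([O-])c1cc(C(F)(F)F)cc([N+](=O)[O-])c1Oc1ccccc1/C=N\OCc1ccccc1F` carries fluoro in place of hydrogen on an aromatic carbon and in this assay compound 2 gives 700 nM, a step of a 1.9-fold lower number from compound 1 to compound 2 (0.28 log units; within the scatter). Compound 3 `O=[N+]([O-])c1cc(C(F)(F)F)cc([N+](=O)[O-])c1Oc1c(Cl)cc(Cl)cc1/C=N\OCc1ccccc1` has a different core; the difference between the two cores is not broken down here. In this assay compound 3 gives 1210 nM, within the scatter of compound 1. Compound 4 `O=[N+]([O-])c1cc(C(F)(F)F)cc([N+](=O)[O-])c1Oc1c(Cl)cc(Cl)cc1/C=N\OCc1ccccc1F` carries the same change on the core of compound 3, (fluoro in place of hydrogen on an aromatic carbon). For the measured compounds named here, for compound 4 the expected step in this assay is a 1.6-fold lower number from compound 3 to compound 4 (0.21 log units; within the scatter), resting on the single earlier instance a 1.9-fold lower number from compound 1 to compound 2 (0.28 log units; within the scatter), which itself lies within the scatter, so the expectation is loose. Compound 4 is estimated at 750 nM in this assay. For compound 4 the expected range runs from 350 nM to 1600 nM.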

Compound 4, half-maximal inhibitory concentration: 800 nM
Beside the measured number, compound 4's estimate is 1.1-fold (0.03 log units) below it, and the stated range covers the measured number.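

In this assay, benzyl to 2-fluorobenzyl on the core of compound 3 gives a 1.5-fold lower number from compound 3 to compound 4 (0.18 log units; within the scatter). Set beside the earlier step, the change carries from one core to the other with no difference that can be told apart: the same change on two cores in this assay, a 1.9-fold lower number (0.28 log units; within the scatter) from compound 1 to compound 2 and a 1.5-fold lower number (0.18 log units; within the scatter) from compound 3 to compound 4, 1.3-fold (0.10 log units) apart, within the scatter of two such steps. Each step lies within the scatter, so the pair does not show that fluoro gives a real gain on either core, and two cores say nothing about any further core in the series.

The compounds shown leave open what a methoxy group, an amine or a carboxylic acid in place of fluoro would give on these two cores. They also leave open whether any such group would give a step beyond the scatter.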